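From Phenyl to Isopropyl on a Ring Nitrogen

The source may report more compounds than this note shows. Statements on the series, on what has been measured and on what is new or still open speak of the compounds shown alone.

Within the data shown here, in a functional assay on HCT-116 cells (Homo sapiens) for antiproliferative activity, read by MTT assay, with a stated time of 72 h (on this read-out higher numbers stand for weaker inhibition and lower numbers for stronger inhibition), compound 2 `COc1ncc(-c2ccc3c(c2)N(c2ccccc2)C(=O)CO3)cc1NS(=O)(=O)c1ccc(F)cc1` gives 18800 nM and has only one measured neighbour. Compound 1 `CC(C)N1C(=O)COc2ccc(-c3cnc(Cl)c(NS(=O)(=O)c4ccc(F)cc4)c3)cc21` gives 18900 nM within the scatter of that number, so neither compound can be ranked above the other. Compound 3 `COc1ncc(-c2ccc3c(c2)N(C(C)C)C(=O)CO3)cc1NS(=O)(=O)c1ccc(F)cc1` differs from compound 2 in one place, with isopropyl in place of phenyl on an amide-type nitrogen in a ring is the counted change. Among the measured compounds shown here, no two measured compounds differ in just one place, so the data do not show directly what this swap does in this assay and any forecast is uncertain. A small shift towards stronger inhibition, about the size of the scatter, is expected, and the estimated change is a 1.9-fold lower number from compound 2 to compound 3 (0.27 log units; within the scatter) for this swap. For compound 3 the estimated value is 10000 nM with an expected range from 3000 nM to 30000 nM at this stage.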

Compound 3, half-maximal inhibitory concentration: 19200 nM
For compound 3 the middle estimate is 1.9-fold (0.28 log units) below the measured one, within the range that was stated.
By their numbers in this assay, from the lowest: compounds 2, 1 and 3 (each within the scatter of the next).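

In this assay the swap on the amide-type nitrogen, with isopropyl in place of phenyl, gives a 1.0-fold higher number from compound 2 to compound 3 (0.01 log units; within the scatter) and so shows that removing the six-membered aromatic ring from this position leaves the number within the scatter. With isopropyl held on that nitrogen, methoxy in place of chloro on an aromatic carbon gives a 1.0-fold higher number from compound 1 to compound 3 (0.01 log units; within the scatter) and is likewise too small a step to read as a change in either direction. Nothing measured here speaks to why these two swaps leave the numbers so close. Going by these compounds, all three compounds sit within the scatter of one another, so it remains open whether any group on this nitrogen can shift the number beyond the scatter. A carboxylic acid or an amine on a longer chain at this nitrogen would be a very different kind of group from phenyl and isopropyl, and its effect cannot be judged from these compounds.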